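The source may report more compounds than this note shows. Statements on the series, on what has been measured and on what is new or still open speak of the compounds shown alone.

Compound 2 `CCCCCN1C(=O)C/C(=C\c2cccc(C(=O)Nc3cccc(CC)c3)c2)C1=O` and compound 1 `CCc1cccc(NC(=O)c2cccc(/C=C3\CC(=O)N(c4ccccc4)C3=O)c2)c1` share one core and differ only at the amide-type nitrogen in the ring. In an ADME assay on SW480 cells (Homo sapiens) for cytotoxicity, read by MTT assay, with a stated time of 72 h (a lower number here means a stronger inhibitor, a higher number a weaker inhibitor), compound 1 gives 88600 nM, and compound 2 gives 83300 nM. The step of a 1.1-fold lower number from compound 1 to compound 2 (0.03 log units; within the scatter) lies within the usual scatter, so the two compounds stand side by side, with neither set apart from the other. Compound 3 `CCCCCN1C(=O)C/C(=C\c2cccc(C(=O)Nc3ccc(OC)cc3)c2)C1=O` keeps the pentyl of compound 2 and changes the other end of the molecule: 4-methoxyphenyl in place of 3-ethylphenyl on an amide-type nitrogen. For the measured compounds named here, no measured step concerns this amide nitrogen; the one step seen so far sits at the ring nitrogen and gives no guidance here. The only pointer is that both measured compounds give similar numbers, so the expected step is a 1.0-fold higher number from compound 2 to compound 3 (0.01 log units; within the scatter), nothing beyond the scatter. Compound 3 is therefore estimated to give 85000 nM in this assay, with a range from 40000 nM to 180000 nM.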

Compound 3, half-maximal inhibitory concentration: > 100000 nM
Compound 3 was reported as a limit; the forecaster's own chance of this, stated with the estimate: 20%; middle value at least 1.1-fold (0.07 log units) from the limit.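

At the amide-type nitrogen, putting 4-methoxyphenyl in place of 3-ethylphenyl gives an at least 1.2-fold higher number from compound 2 to compound 3 (0.07 log units; that floor lies within the scatter), so this first measured change at this position yields only a floor, and that floor does not set the two compounds apart. For compound 3, the entry > 100000 nM in this assay is a limit and not a number. Going by these compounds, the true size of the step stays unknown, because the reading for compound 3 is only a limit: the limit of > 100000 nM in this assay, at which 1 of the 3 values shown sits.

On these data alone, it remains open whether 3-methoxyphenyl would separate the effect of the methoxy group from that of its place on the ring. It is also open whether a dimethylamino group or a carboxylic acid on this phenyl ring would give a lower number in this cell assay than those shown.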